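This account rests on a few compounds, and the source may have more. Where it says the series, first, only, none or still open, it means among the compounds named here.

Of the compounds shown here, two have so far been tested in a functional assay on the whole organism (artery, strain albino) with Rattus norvegicus as the target, with a stated time of 60 min, at a dose of 10 mg/kg by the oral route; on this read-out higher numbers stand for more inhibition at the one dose given (going by the name of the read-out) and lower numbers for less inhibition. Compound 1 `COc1ccc(C2N=C(SCc3ccc(F)cc3)NC(C)=C2C(=O)Nc2ccc(F)cc2)cc1OC` gives 11.8%. Compound 2 `CC1=C(C(=O)Nc2ccc(Br)cc2)C(c2ccc(Cl)cc2Cl)N=C(SCc2ccccc2)N1` gives 6.7%, the lowest of the two numbers, though its gap to compound 1 lies within the usual scatter, so the two cannot be told apart. Compound 3 `CC1=C(C(=O)Nc2ccc(Br)cc2)C(c2ccc(Cl)cc2Cl)N=C(SCc2ccccc2Cl)N1` has not yet been measured in this assay. It differs from compound 2 in one place: chloro in place of hydrogen on an aromatic carbon. For the measured compounds named here, no pair of measured compounds differs in a single place, so there is no measured step to lean on. Both measured numbers sit low, and on that basis the step from compound 2 to compound 3 is expected to be small, a number 1.3 percentage points higher from compound 2 to compound 3 (within the scatter), not beyond the scatter in either direction. Compound 3 is accordingly estimated at 8%, with a range from 0% to 20%.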

Compound 3, a percentage reported as inhibition, in the whole organism at one dose (the size of the read-out at that dose, not a potency): 11.8%
For compound 3 the middle estimate is 3.8 percentage points below the measured one, within the range that was stated.
By their numbers in this assay, from the lowest: compounds 2, 1 and 3 (each within the scatter of the next).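

For the compounds shown here, the change from benzyl to 2-chlorobenzyl gives the first single-place step in this assay, and it reads a number 5.1 percentage points higher from compound 2 to compound 3 (within the scatter) on the shared core. At this aromatic carbon, ortho to a large group, chloro in place of hydrogen therefore gives a compound that cannot be told apart from its parent, so this one change shows no clear effect on the read-out at this dose. Nothing available bears on the reason for this result.

One step at one carbon leaves open how chloro would read elsewhere on that ring. From the compounds shown here alone, it is also open whether an amine or a carboxylic acid at this carbon, or a longer chain in place of the benzyl, would give a step beyond the scatter.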